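The compounds below may be only part of what the source reports. "The series", "measured", "known", "first", "only" and "open" are said of these compounds alone.

In a functional assay on A549 cells (Homo sapiens) for cytotoxicity, read by MTT assay, with a stated time of 72 h (on this read-out lower numbers stand for stronger inhibition and higher numbers for weaker inhibition), compound 1 `O=C(Nc1ccc(Oc2ccnc3[nH]ccc23)cc1)c1nn(-c2ccc(Cl)c(F)c2)ccc1=O` gives 2580 nM. Compound 2 `COc1ccc(-n2ccc(=O)c(C(=O)Nc3ccc(Oc4ccnc5[nH]ccc45)c(F)c3)n2)cc1` reaches only a limit of the assay, reported as > 60000 nM. Compound 3 `O=C(Nc1ccc(Oc2ccnc3[nH]ccc23)c(F)c1)c1nn(-c2ccc(Br)cc2)ccc1=O` likewise reaches only a limit, reported as > 60000 nM. Compound 3 therefore stands at the edge of what this assay can report, a position it shares with one other compound (the limit of > 60000 nM in this assay, at which 2 of the 3 values shown sit). Among the measured compounds shown here, the only single-point step among the measured compounds, a step that the two limits leave unreadable from compound 2 to compound 3, runs between two such limits, so its size cannot be read.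

Compound 4 `O=C(Nc1ccc(Oc2ccnc3[nH]ccc23)c(F)c1)c1nn(-c2ccc(Cl)c(F)c2)ccc1=O` has not yet been measured. It differs from compound 3 by 4-chloro-3-fluorophenyl in place of 4-bromophenyl on an aromatic nitrogen. For the measured compounds named here, no measured step bears directly on this exchange. What can be said is that compound 1 carries the same 4-chloro-3-fluorophenyl group and gives a readable 2580 nM in this assay. Compound 2 and compound 3, which carry other groups on that aromatic nitrogen, reach only the limit.

On that basis compound 4 is expected to come in near 20000 nM, within a range from 4000 nM to 80000 nM. The step from compound 3 to compound 4 is thus estimated as an at least 3.0-fold lower number from compound 3 to compound 4 (0.47 log units; beyond the scatter), toward stronger inhibition, though a limit remains a real possibility.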

Compound 4, half-maximal inhibitory concentration: 10300 nM
Compound 4: the middle estimate sits 1.9-fold (0.29 log units) above what was measured; the measured number falls inside the stated range.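

In this assay, the group on the aromatic nitrogen can bring a compound back from the limit to a readable value while the rest of the molecule stays the same: replacing 4-bromophenyl with 4-chloro-3-fluorophenyl gives an at least 5.8-fold lower number from compound 3 to compound 4 (0.76 log units; beyond the scatter), and replacing 4-methoxyphenyl with the same group gives an at least 5.8-fold lower number from compound 2 to compound 4 (0.76 log units; beyond the scatter). These two sizes are only lower bounds because each starting compound sits at a limit of the assay rather than at a true number: the limit of > 60000 nM in this assay, at which 2 of the 4 values shown sit. The fluoro on the aromatic carbon also matters, since fluoro in place of hydrogen gives a 4.0-fold higher number from compound 1 to compound 4 (0.60 log units; beyond the scatter), toward weaker inhibition, so the readable value depends on more than the group on the aromatic nitrogen.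

Among the compounds shown here, with that fluoro in place, only three groups appear on the aromatic nitrogen, so it stays open whether the gain belongs to the chloro, to the fluoro on that phenyl ring, or to the two together. The compounds shown also leave open how a phenyl ring carrying an amine or a carboxylic acid, or a benzyl group on that nitrogen, would behave in this assay.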